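A few compounds are considered here, and "the series" means these few. Any claim that something is new, unique, unknown or untested is made for them only; others in the source may bear on it.

Of the compounds shown here, two have been measured in an ADME assay on NIH3T3 cells (Mus musculus) for cytotoxicity, read by XTT assay, with a stated time of 8 days; a higher number here means that more compound is tolerated, a lower number that less compound is tolerated. Compound 1, `CC(=O)OC[C@H]1O[C@@H](n2c(Br)nc3c(Cl)c(Cl)c(Cl)cc32)[C@H](OC(C)=O)[C@@H]1OC(C)=O`, carries acetyl groups on its sugar part and a halogenated core; in this assay compound 1 gives 15100 nM. Compound 2, `OC[C@H]1O[C@@H](n2c(Br)nc3cc(Cl)c(Cl)cc32)[C@H](O)[C@@H]1O`, has free hydroxyl groups instead and a differently substituted core; in this assay compound 2 gives 88100 nM. Of these two numbers, compound 1 stands lowest, and compound 2 lies clearly higher, beyond the usual scatter, so the cells tolerate less of compound 1 than of compound 2. The two compounds differ in several places at once, so their gap cannot be tied to any single change.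

Compound 3, `CC(=O)OC[C@H]1O[C@@H](n2c(Cl)nc3c(Cl)c(Cl)c(Cl)cc32)[C@H](OC(C)=O)[C@@H]1OC(C)=O`, is compound 1 with one alteration: chloro in place of bromo on an aromatic carbon. Among the measured compounds shown here, none of the measured compounds shows what this exchange of one halogen for another does, so no step beyond the scatter is expected in either direction. The step expected from this change, a 1.1-fold higher number from compound 1 to compound 3 (0.05 log units; within the scatter), is therefore close to none. Compound 3 is estimated at 17000 nM in this assay, within a range from 6000 nM to 50000 nM.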

Compound 3, half-maximal cytotoxic concentration: 39600 nM
Compound 3: middle estimate off by 2.3-fold (0.37 log units), on the low side; measured number inside the range.
By their numbers in this assay, from the lowest: compound 1; then compound 3; then compound 2.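

Among the compounds shown here, compound 1 and compound 3 differ in one place only, so this is the first gap here that can be tied to a single change, unlike the gap between compound 1 and compound 2, which differ in several places. In this assay, putting chloro in place of bromo on the aromatic carbon between two ring nitrogen atoms gives a 2.6-fold higher number from compound 1 to compound 3 (0.42 log units; beyond the scatter), a modest step, but it shows that even an exchange of one halogen for another at this position can move the number, and that the cells tolerate more of the chloro compound. No measurement at hand explains why this exchange has this effect.

From the compounds shown here alone, it remains open whether the same exchange would give a step of similar size on compound 2, with its free hydroxyl groups and differently substituted core, as this is a single pair on a single acetylated compound. Going by these compounds, it is also open how this position would respond to a group other than a halogen, such as a methyl group or an amine.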